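Cytotoxicity of Compounds 1 to 3 and an Expected Fourth

The source may report more compounds than this note shows. Statements on the series, on what has been measured and on what is new or still open speak of the compounds shown alone.

Compound 1 `Cc1cccc(-c2cc(C(=O)N3CCC(Cc4ccccc4)CC3)c3ccccc3n2)c1`: > 20000 nM
Compound 2 `Cc1ccc([C@H](C)NC(=O)c2cc(-c3cccc(C)c3)nc3ccccc23)cc1`: > 20000 nM
Compound 3 `CC(C)Cc1ccc(-c2cc(C(=O)N3CCC(Cc4ccccc4)CC3)c3ccccc3n2)cc1`: > 20000 nM

In an ADME assay on HepG2 2.2.15 cells (Homo sapiens) for cytotoxicity, read by MTT assay, with stated times of 3 days and 7 days (on this read-out higher numbers stand for lower toxicity in this test and lower numbers for higher toxicity in this test), each of these three values is a limit of the test rather than a number. Compound 3 therefore stands only at a limit, as do the other two (the limit of > 20000 nM in this assay, at which 3 of the 3 values shown sit). The step that the two limits leave unreadable from compound 1 to compound 3 cannot be read, because both ends are limits. Compound 4 `CCOc1cccc(-c2cc(C(=O)N3CCC(Cc4ccccc4)CC3)c3ccccc3n2)c1` differs from compound 3 by 3-ethoxyphenyl in place of 4-isobutylphenyl on an aromatic carbon. Among the measured compounds shown here, no measured step bears readably on this change, since the only step available sits between two limits. With all three values at the limit, no change beyond the scatter is expected for a step that the limit leaves unreadable from compound 3 to compound 4. Compound 4 is thus estimated at 30000 nM, within 15000 nM to 80000 nM, and is expected most likely to be reported again only as a limit.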

Compound 4, half-maximal cytotoxic concentration: > 20000 nM
Compound 4: no number, only a limit; the forecaster's own chance of this, stated with the estimate: 85%; the middle value does not contradict the limit.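

In this assay compound 4 gives > 20000 nM, which is a limit, so the steps to it from compound 1 and compound 3 cannot be read: the limit of > 20000 nM in this assay, at which 4 of the 4 values shown sit. The compounds shown leave open whether any of these changes alters cytotoxicity at all.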